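A few compounds are considered here, and "the series" means these few. Any claim that something is new, unique, unknown or untested is made for them only; others in the source may bear on it.

Series notes. In an ADME assay on the whole organism (strain albino) for activation, with Mus musculus as the target, with stated times of 30 min, 120 min and 240 min (on this read-out lower numbers stand for an effect already at smaller amounts and higher numbers for an effect only at larger amounts of compound), compound 2 `NC(=O)c1ccccc1OCCCCN1CCN(c2ccccc2)CC1` gives only a limit, > 60 mg/kg. In this assay compound 1 `COc1ccccc1N1CCN(CCCOc2ccccc2C(N)=O)CC1` likewise gives only a limit, > 60 mg/kg. Going by the values given here, compound 2 thus stands at the limit of > 60 mg/kg in this assay, at which 2 of the 2 values shown sit, and no step between measured compounds can be drawn. Compound 3 `COc1ccccc1N1CCN(CCCCOc2ccccc2C(N)=O)CC1` differs from compound 2 by methoxy in place of hydrogen on an aromatic carbon. Among the compounds with values here, with no measured step to lean on, the step that the limit leaves unreadable from compound 2 to compound 3 in this assay is expected to stay within the scatter. Compound 3 is accordingly estimated at 80 mg/kg, within 40 mg/kg to 200 mg/kg, most likely again returned as a limit.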

Compound 3, dose for half-maximal effect: > 70 mg/kg
Compound 3 was reported as a limit; the forecaster's own chance of this, stated with the estimate: 75%; the middle value does not contradict the limit.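

No step can be read from compound 2 to compound 3, as each is reported only as a limit. The compounds shown leave open whether methoxy in place of hydrogen on an aromatic carbon alters the read-out at all.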